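The compounds below may be only part of what the source reports. "The series", "measured", "known", "first", "only" and "open" are said of these compounds alone.

For the measured compounds named here, compound 2 `O=C(Nc1ccnnc1)c1cc(N2CCCC2)ccc1OCc1ccccc1` stands lowest of the two numbers so far in an assay on Sf9 cells for inhibition of Leucine-rich repeat serine/threonine-protein kinase 2 (Homo sapiens), read by TR-FRET, with stated times of 30 min and 2 h (a lower number here means a stronger inhibitor, a higher number a weaker inhibitor), where compound 2 gives 20 nM. Compound 1 `O=C(Nc1ccnnc1)c1cc(N2C[C@H]3COC[C@H]3C2)ccc1OCc1ccccc1` gives 50.1 nM in this assay. Compound 3 `O=C(Nc1ccnnc1)c1cc(N2CCC(O)CC2)ccc1OCc1ccccc1` differs from compound 2 by 4-hydroxypiperidin-1-yl in place of pyrrolidin-1-yl on an aromatic carbon. Going by the values given here, only one measured step bears on this change, a 2.5-fold lower number from compound 1 to compound 2 (0.40 log units; beyond the scatter), a modest step beyond the scatter in which the group with more heavy atoms gave the higher number; since the entering group again carries more heavy atoms than the pyrrolidin-1-yl it replaces, a modest rise is expected, a 1.8-fold higher number from compound 2 to compound 3 (0.24 log units; within the scatter). Compound 3 is therefore estimated at 35 nM, within 12 nM to 100 nM.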

Compound 3, half-maximal inhibitory concentration: 39.8 nM
Compound 3: middle estimate off by 1.1-fold (0.06 log units), on the low side; low and high end bracket the measured number.
By their numbers in this assay, from the lowest: compounds 2, 3 and 1 (each within the scatter of the next, the first and the last beyond it).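

At this aromatic carbon, para to the benzyloxy group, 4-hydroxypiperidin-1-yl can stand in place of pyrrolidin-1-yl with only a step inside the scatter in this assay (a 2.0-fold higher number from compound 2 to compound 3 (0.30 log units; within the scatter)). The group of compound 1 and 4-hydroxypiperidin-1-yl also remain within the scatter of each other (a 1.3-fold lower number from compound 1 to compound 3 (0.10 log units; within the scatter)), although the group of compound 3 has one ring and a hydrogen-bond donor. No measurement at hand offers an explanation for these numbers.

Ring size and the hydroxy group change together here, so their separate contributions remain open. Plain piperidin-1-yl or 3-hydroxypyrrolidin-1-yl would separate the two.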